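A few compounds are considered here, and "the series" means these few. Any claim that something is new, unique, unknown or untested is made for them only; others in the source may bear on it.

Compound 1 `Cc1ccc(C(=O)N/N=C/c2c(C)nn(-c3ccccc3)c2Cl)cc1` and compound 2 `COc1ccc(C(=O)N/N=C/c2c(C)nn(-c3ccccc3)c2Cl)cc1` return no number in a functional assay on the whole organism (strain albino) with Mus musculus as the target, with a stated time of 4 h; on this read-out higher numbers stand for an effect only at larger amounts of compound and lower numbers for an effect already at smaller amounts: compound 1 is reported as "not active" (no number reported), and compound 2 is likewise reported as "not active" (no number reported). Among the measured compounds shown here, compound 3 `Cc1nn(-c2ccccc2)c(Cl)c1/C=N/NC(=O)c1ccccc1` is therefore the only member of the shared core with a number at all; in this assay compound 3 gives 300 mg/kg. Compound 4 `Cc1nn(-c2ccccc2)c(Cl)c1/C=N/NC(=O)COc1ccccc1` has not been tested. It differs from compound 3 by phenoxymethyl in place of phenyl on a carbonyl carbon. For the measured compounds named here, no step between measured compounds bears on this change, so the data give no direction for it. The step from compound 3 to compound 4 is expected to be no change at the digits printed from compound 3 to compound 4 (within the scatter), which is none beyond the usual scatter. Compound 4 is estimated at 300 mg/kg in this assay, with a range from 100 mg/kg to 1000 mg/kg.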

Compound 4, dose for half-maximal effect: 100 mg/kg
For compound 4 the middle estimate is 3.0-fold (0.48 log units) above the measured one; the measured number falls inside the stated range.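

Among the compounds shown here, the change of phenyl to phenoxymethyl on a carbonyl carbon gives a 3.0-fold lower number from compound 3 to compound 4 (0.48 log units; beyond the scatter) in this assay, the first measured step. This position therefore accepts the larger group, and the effect appears at a smaller dose. Nothing given here accounts for the shift.

It remains open whether the ring oxygen-linked chain as a whole matters or only its ether oxygen, since benzyl, with no oxygen, does not appear among these compounds. On these data alone, how a longer chain such as phenoxyethyl or an amine such as aminomethyl would behave at this position also stays open.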